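A Small Methyl Step Tested on a Second Core

The compounds below may be only part of what the source reports. "The series", "measured", "known", "first", "only" and "open" are said of these compounds alone.

Compound 1 `COc1ccc(Br)cc1CCc1c(Cl)cccc1-c1nccn1C(C)C` and compound 2 `CCC(C)n1ccnc1-c1cccc(Cl)c1CCc1cc(Br)ccc1OC` share one core and differ in a single place: methyl in place of hydrogen on a saturated chain carbon, two bonds along the chain from an aromatic nitrogen. In a functional assay on HEK293 cells (Homo sapiens), read by cAMP accumulation (on this read-out higher numbers stand for weaker inhibition and lower numbers for stronger inhibition), compound 1 gives 1400 nM, while compound 2 gives 2100 nM, so the step of a 1.5-fold higher number from compound 1 to compound 2 (0.18 log units; within the scatter). Compound 3 `COc1ccc(Br)cc1CCc1ccccc1-c1ncc(C)n1C` has a core whose difference from compound 1 is not broken down here; in this assay compound 3 gives 51 nM, the lowest of the three measured numbers. Compound 4 `CCc1cnc(-c2ccccc2CCc2cc(Br)ccc2OC)n1C` arises from compound 3 by methyl in place of hydrogen on a saturated chain carbon bound to an aromatic carbon. This is the same kind of change, though the place differs: in compound 2 the saturated chain carbon lies two bonds along the chain from an aromatic nitrogen, whereas in compound 4 it is bound to an aromatic carbon. Because the earlier step of a 1.5-fold higher number from compound 1 to compound 2 (0.18 log units; within the scatter) stayed within the scatter, a similarly small step is expected for compound 4, a 1.4-fold higher number from compound 3 to compound 4 (0.14 log units; within the scatter). Compound 4 is estimated at 70 nM, likely between 30 nM and 170 nM.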

Compound 4, half-maximal inhibitory concentration: 170 nM
The estimate for compound 4 lay 2.4-fold (0.39 log units) below the measured number, and the stated range covers the measured number.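

On the core of compound 3, methyl in place of hydrogen on a saturated chain carbon bound to an aromatic carbon gives a 3.3-fold higher number from compound 3 to compound 4 (0.52 log units; beyond the scatter), a loss of inhibition larger than the usual scatter. Set beside the earlier step on the other core, this step does not clearly differ from it: the same change on two cores in this assay, a 1.5-fold higher number (0.18 log units; within the scatter) from compound 1 to compound 2 and a 3.3-fold higher number (0.52 log units; beyond the scatter) from compound 3 to compound 4, 2.2-fold (0.35 log units) apart, within the scatter of two such steps. The change therefore carries across these two cores without a clear difference in its effect, but this does not show that the two steps are equal, and the added methyl sits in a different place on each core, so two pairs make no rule for the series.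

Still open, going by these compounds, is whether a longer chain, such as propyl, in place of the ethyl of compound 4 would weaken inhibition further. On these data alone, an amine or a carboxylic acid at the end of that chain is equally open.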